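The source may report more compounds than this note shows. Statements on the series, on what has been measured and on what is new or still open speak of the compounds shown alone.

Compound 1 `Nc1nc(OCC(F)(F)F)c2ncn(/C=C3/CC3(CO)CO)c2n1` — in an ADME assay on CCRF-HSB-2 cells (Homo sapiens) for cytotoxicity, with a stated time of 7 days (on this read-out higher numbers stand for lower toxicity in this test and lower numbers for higher toxicity in this test), compound 1 reaches only the assay limit, > 20000 nM.
Compound 2 `COCCOc1nc(N)nc2c1ncn2/C=C1/CC1(CO)CO` — in this assay compound 2 likewise reaches only a limit, > 20000 nM.
Compound 3 `CC(C)Nc1nc(N)nc2c1ncn2/C=C1/CC1(CO)CO` — in this assay compound 3 also stops at a limit, > 20000 nM.

Compound 3 therefore stands where every measured member of the series stands: at a limit rather than a number, and the two other values are limits as well, all three sitting at the limit of > 20000 nM in this assay, at which 3 of the 3 values shown sit. The changes among the measured compounds tell nothing about size or direction: from compound 1 to compound 2 the step is a step that the two limits leave unreadable from compound 1 to compound 2, from compound 1 to compound 3 it is a step that the two limits leave unreadable from compound 1 to compound 3, and from compound 2 to compound 3 it is a step that the two limits leave unreadable from compound 2 to compound 3.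

Compound 4 `CCCCOc1nc(N)nc2c1ncn2/C=C1/CC1(CO)CO` differs from compound 3 by butoxy in place of isopropylamino on an aromatic carbon. Within the data shown here, none of the measured steps is readable, so none gives a size to carry over; the only pattern the three compounds show is that every variation of this group so far has stayed at the limit, and no measured compound goes against that. The expectation is that compound 4 behaves the same way in this assay, with no step beyond the scatter, so the expected step from compound 3 is a step that the limit leaves unreadable from compound 3 to compound 4. Compound 4 is estimated at 30000 nM, within 15000 nM to 80000 nM, most likely reported again only as a limit.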

Compound 4, half-maximal cytotoxic concentration: > 20000 nM
Compound 4 gave a limit, no number (the forecaster's own chance of this, stated with the estimate: 85%); the middle value does not contradict the limit.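

Compound 4 adds no readable step: its comparisons with compound 1, compound 2 and compound 3 in this assay set limit against limit, and no number is available from any of them: the limit of > 20000 nM in this assay, at which 4 of the 4 values shown sit. The compounds shown leave open how far past that limit each compound lies, and whether any group at this place would give a measurable value.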